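This account rests on a few compounds, and the source may have more. Where it says the series, first, only, none or still open, it means among the compounds named here.

Notes on the series. In a functional assay on the whole organism with Rattus norvegicus as the target (a higher number here means that more compound is needed for the effect, a lower number that less compound is needed), compound 1 `Nc1nc2ccc(CC(F)(F)F)cc2s1` gives 8 mg/kg. Compound 2 `COC(=O)Cn1c(=N)sc2cc(OC(F)(F)F)ccc21` reaches only a limit in this assay, > 10 mg/kg. Compound 3 `C[S+]([O-])Cn1c(=N)sc2cc(OC(F)(F)F)ccc21` gives 2.3 mg/kg in this assay, the lowest of the two numbers, with compound 1 the nearest. Among the measured compounds shown here, the single measured step, an at least 4.3-fold lower number from compound 2 to compound 3 (0.63 log units; beyond the scatter), involves one value at the limit of > 10 mg/kg in this assay, at which 1 of the 3 values shown sits.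

Compound 4 `CC[S+]([O-])CCn1c(=N)sc2cc(OC(F)(F)F)ccc21` differs from compound 3 by a group of 5 heavy atoms (3 carbon, 1 oxygen, 1 sulfur; no ring) in place of a group of 3 heavy atoms (1 carbon, 1 oxygen, 1 sulfur; no ring), on a saturated chain carbon bound to an aromatic nitrogen. For the measured compounds named here, no measured step covers this kind of change; the step from compound 2 to compound 3 exchanges the group rather than extending it, so it gives no direction here. The expected step, a 1.3-fold higher number from compound 3 to compound 4 (0.12 log units; within the scatter), is none beyond the scatter. Compound 4 is estimated at 3 mg/kg, with a range from 1.2 mg/kg to 8 mg/kg.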

Compound 4, dose for half-maximal effect: 1.2 mg/kg
Estimate against measurement, compound 4: 2.5-fold (0.40 log units) above, and the stated range covers the measured number.
By their numbers in this assay, from the lowest: compounds 4 and 3 (each within the scatter of the next); then compound 1. At a limit, above all of these: compound 2.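

Working from the sulfur-bearing groups, the group of 5 heavy atoms is accommodated on the saturated chain carbon bound to an aromatic nitrogen, with the number staying level with that of the group of 3 heavy atoms in this assay: a 1.9-fold lower number from compound 3 to compound 4 (0.28 log units; within the scatter). The group of 5 heavy atoms also separates from the group of 4 heavy atoms, with an at least 8.3-fold lower number from compound 2 to compound 4 (0.92 log units; beyond the scatter). That step starts from compound 2, whose entry is a limit and not a number: the limit of > 10 mg/kg in this assay, at which 1 of the 4 values shown sits.

As far as these compounds go, whether a longer chain keeps this level remains open. So does the outcome with an amine or a carboxylic acid at this place.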